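Thiosemicarbazide series on one cell line: ring size at the thiocarbonyl

A few compounds are considered here, and "the series" means these few. Any claim that something is new, unique, unknown or untested is made for them only; others in the source may bear on it.

Compound 1 `Cc1cccc(/C(N)=N/NC(=S)N2CCCCC2)n1` and compound 2 `Cc1cccc(/C(N)=N/NC(=S)N2CCCC2)n1` share a core and differ in one place: pyrrolidin-1-yl in place of piperidin-1-yl on a thiocarbonyl carbon. In a functional assay on MCF7 cells (Homo sapiens) for cytotoxicity, read by MTT assay, with a stated time of 72 h, tested at 100 uM (a lower number here means less inhibition of growth, a higher number more inhibition of growth at the concentration tested), compound 1 gives 54% and compound 2 gives 61.8%, so the step of a number 7.8 percentage points higher from compound 1 to compound 2 (within the scatter) lies within the scatter. Compound 3 `Cc1ccnc(/C(N)=N/NC(=S)N2CCCCC2)c1` has the same atoms as compound 1 joined differently; the difference between the two cores is not broken down here. In this assay compound 3 gives 80.1%, the highest of the three numbers, beyond the scatter from both compound 1 and compound 2.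

Compound 4 `Cc1ccnc(/C(N)=N/NC(=S)N2CCCC2)c1` is not yet measured. It is related to compound 3 by pyrrolidin-1-yl in place of piperidin-1-yl on a thiocarbonyl carbon, the same change as from compound 1 to compound 2, at the same place. Because that change gave a number 7.8 percentage points higher from compound 1 to compound 2 (within the scatter), a step within the scatter is expected here too, so the estimated step is a number 3.9 percentage points higher from compound 3 to compound 4 (within the scatter). The estimate rests on one earlier pair only, on a different core, so it is held loosely. Compound 4 is expected to give about 84% in this assay, with a likely span from 70% to 95%.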

Compound 4, percent growth inhibition at one concentration: 87.7%
The estimate for compound 4 lay 3.7 percentage points below the measured number, and the stated range covers the measured number.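

In this assay, the new step is a number 7.6 percentage points higher from compound 3 to compound 4 (within the scatter), and it sits with the earlier step on the other core: the same change on two cores in this assay, a number 7.8 percentage points higher (within the scatter) from compound 1 to compound 2 and a number 7.6 percentage points higher (within the scatter) from compound 3 to compound 4, 0.2 percentage points apart, within the scatter of two such steps

Across these two pairs, pyrrolidin-1-yl in place of piperidin-1-yl on a thiocarbonyl carbon behaves alike on both cores, so the step carries from one core to the other with no detectable difference. Both steps lie within the scatter, however, so the pairs do not show that this change alters growth inhibition at all, and two cores give no rule for any further core in the series.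

The compounds shown carry only these two rings on the thiocarbonyl carbon, leaving open how a morpholin-4-yl group, a dimethylamino group or an open-chain amine would read there. Also open, from the compounds shown here alone, is whether a carboxylic acid or a longer chain in place of the methyl group on the core would leave this step unchanged.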